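A few compounds are considered here, and "the series" means these few. Any claim that something is new, unique, unknown or untested is made for them only; others in the source may bear on it.

Measured compounds:
- compound 1, `OC[C@H]1O[C@@H](n2cnc3c(NCc4cccc(F)c4)ncnc32)[C@H](O)[C@@H]1O`: 7600 nM
- compound 2, `OC[C@H]1O[C@@H](n2cnc3c(NCc4ccccc4Cl)ncnc32)[C@H](O)[C@@H]1O`: 64000 nM
- compound 3, `OC[C@H]1O[C@@H](n2cnc3c(NCc4ccc(Cl)cc4)ncnc32)[C@H](O)[C@@H]1O`: 218000 nM

In a functional assay on K562 cells (Homo sapiens) for antiproliferative activity, with a stated time of 72 h (a higher number here means a weaker inhibitor, a lower number a stronger inhibitor), compound 1 gives 7600 nM, compound 2 gives 64000 nM and compound 3 gives 218000 nM. Compound 2 thus stands second highest of the three, with compound 3 nearest above it and compound 1 furthest below it; the step of a 3.4-fold higher number from compound 2 to compound 3 (0.53 log units; beyond the scatter) and the step of an 8.4-fold higher number from compound 1 to compound 2 (0.93 log units; beyond the scatter) both lie beyond the scatter.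

Compound 4, `COc1cc(CNc2ncnc3c2ncn3[C@@H]2O[C@H](CO)[C@@H](O)[C@H]2O)cc(OC)c1`, differs from compound 2 only at the group on the saturated chain carbon bound to a nitrogen on the aromatic ring: 3,5-dimethoxyphenyl in place of 2-chlorophenyl on a saturated chain carbon bound to a nitrogen on an aromatic ring. Among the measured compounds shown here, the steps that bear on this position, an 8.4-fold higher number from compound 1 to compound 2 (0.93 log units; beyond the scatter), a 29-fold higher number from compound 1 to compound 3 (1.46 log units; beyond the scatter) and a 3.4-fold higher number from compound 2 to compound 3 (0.53 log units; beyond the scatter), show that exchanging the aryl group here moves the number by a modest to large amount in either direction; none of them involves a methoxy-bearing ring, so the direction for compound 4 is uncertain. A step of moderate size is expected, most likely towards a lower number, a 2.1-fold lower number from compound 2 to compound 4 (0.33 log units; beyond the scatter). Compound 4 is therefore estimated at 30000 nM, within 5000 nM to 200000 nM.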

Compound 4, half-maximal inhibitory concentration: > 166000 nM
Compound 4 gave a limit, no number; the forecaster's own chance of this, stated with the estimate: 10%; middle value at least 5.5-fold (0.74 log units) away from the limit.
By their numbers in this assay, from the lowest: compound 1; then compound 2; then compound 3.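

Compound 4 gives only a limit in this assay, not a number: the limit of > 166000 nM in this assay, at which 1 of the 4 values shown sits.

Even so, the limit shows that the first methoxy-bearing ring at this place sits on the high side of the series, with an at least 2.5-fold higher number from compound 2 to compound 4 (0.41 log units; beyond the scatter) and an at least 21-fold higher number from compound 1 to compound 4 (1.33 log units; beyond the scatter). Exchanging 2-chlorophenyl for 3,5-dimethoxyphenyl thus raises the number, and compound 1 keeps the lowest number of the four, although the step between compound 3 and compound 4 cannot be read.

Still open, from the compounds shown here alone, is how a 3-chlorophenyl or a 3-methoxyphenyl group would stand on this saturated chain carbon, and so whether the low number of compound 1 belongs to its fluorine. Also open, going by these compounds, is how a phenyl ring carrying an amine or a carboxylic acid would compare.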